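This account rests on a few compounds, and the source may have more. Where it says the series, first, only, none or still open, it means among the compounds named here.

Working notes on the series in a functional assay for inhibition, tested at 20 ug/mL; a lower number here means a weaker effect, a higher number a stronger effect of the compound at the concentration tested.

Three compounds share one core, each with a different aryl group ortho to the cyano group. Compound 1 `Cc1cc(O)c(C(C)C)cc1-c1cc(-c2ccccc2)c(C#N)c(=O)[nH]1` gives 22%. Compound 2 `COc1ccc(-c2cc(-c3cc(C(C)C)c(O)cc3C)[nH]c(=O)c2C#N)c(OC)c1` gives 27%. Compound 3 `COc1ccc(-c2cc(-c3cc(C(C)C)c(O)cc3C)[nH]c(=O)c2C#N)cc1` gives 24%. All three numbers lie together: a number 2 percentage points higher from compound 1 to compound 3 (within the scatter), and a number 3 percentage points lower from compound 2 to compound 3 (within the scatter), so none of the three can be set apart from the others on these data.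

Compound 4 `COc1cc(-c2cc(-c3cc(C(C)C)c(O)cc3C)[nH]c(=O)c2C#N)ccc1O` is not yet measured. It differs from compound 3 in one place: 4-hydroxy-3-methoxyphenyl in place of 4-methoxyphenyl on an aromatic carbon.

Within the data shown here, the steps that bear on this change are those that alter methoxy substitution on the same aryl group: a number 2 percentage points higher from compound 1 to compound 3 (within the scatter), and a number 3 percentage points lower from compound 2 to compound 3 (within the scatter). Both are within the scatter, and the step of a number 5 percentage points higher from compound 1 to compound 2 (within the scatter) points the same way. Nothing in the measured set shows that adding or moving an oxygen substituent on this ring shifts the read-out beyond the scatter. The step from compound 3 to compound 4 is therefore expected to be a number 1 percentage points higher from compound 3 to compound 4 (within the scatter), that is, no change beyond the scatter. For compound 4 the expected value in this assay is 25%, with a range from 14% to 36%.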

Compound 4, a percentage reported as inhibition, at one concentration (the size of the read-out at that concentration, not a potency): 26%
For compound 4 the middle estimate is 1 percentage points below the measured one, and the stated range covers the measured number.
By their numbers in this assay, from the lowest: compounds 1, 3, 4 and 2 (each within the scatter of the next).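

A free hydroxy group on the aryl ring ortho to the cyano group is new to the series, and in this assay the change gives a number 2 percentage points higher from compound 3 to compound 4 (within the scatter), so this oxygen substitution pattern does not set compound 4 apart from compound 3. The comparisons with the other aryl groups agree, with a number 1 percentage points lower from compound 2 to compound 4 (within the scatter) and a number 4 percentage points higher from compound 1 to compound 4 (within the scatter), so phenyl, 4-methoxyphenyl, 2,4-dimethoxyphenyl and 4-hydroxy-3-methoxyphenyl cannot be told apart at this position. No supporting data bear on why the read-out stays flat across these aryl groups.

As far as these compounds go, whether an aryl group carrying an amine or a carboxylic acid, or a longer alkyl chain in place of the aryl group, would move the read-out beyond the scatter remains open. Also open, from the compounds shown here alone, is whether these compounds would differ in the strength of their effect at any other concentration, since the read-out comes from a single concentration.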